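A Methoxy Removed While Both Measured Values Sit at the Limit

This account rests on a few compounds, and the source may have more. Where it says the series, first, only, none or still open, it means among the compounds named here.

Compound 1 `C=C1C[C@]23C[C@@]1(O)CC[C@H]2c1ccc(OS(=O)(=O)c2ccc(C)cc2)c(C)c1[C@@H]3Cn1cc(-c2ccc(OC)cc2)nn1`: > 20000 nM in a functional assay on SW480 cells (Homo sapiens) for cytotoxicity, read by MTT assay, with a stated time of 4 days (on this read-out higher numbers stand for weaker inhibition and lower numbers for stronger inhibition), a limit of the assay.
Compound 2 `C=C1C[C@]23C[C@@]1(O)CC[C@H]2c1ccc(O)c(C)c1[C@@H]3Cn1cc(-c2ccc(OC)cc2)nn1`: > 20000 nM in this assay, likewise a limit.

Compound 1 therefore stands at the limit of this assay rather than at a measured number. Compound 2 differs from it by a step that the two limits leave unreadable from compound 1 to compound 2, and the two limits leave the size of that step unreadable. Within the data shown here, the only evidence on the measured values is that (the limit of > 20000 nM in this assay, at which 2 of the 2 values shown sit).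

Compound 3 `C=C1C[C@]23C[C@@]1(O)CC[C@H]2c1ccc(OS(=O)(=O)c2ccc(C)cc2)c(C)c1[C@@H]3Cn1cc(-c2ccccc2)nn1` is the compound still to be measured. It differs from compound 1 by hydrogen in place of methoxy on an aromatic carbon, a small loss that leaves the rest of the structure untouched. Among the measured compounds shown here, no measured step bears directly on this change, and the one step that exists between the measured compounds is itself unreadable. With both known values resting at the limit, compound 3 is expected to give a value at or beyond that limit too, with a step that the limit leaves unreadable from compound 1 to compound 3. Compound 3 is thus estimated at 25000 nM, between 8000 nM and 60000 nM, most likely reported only as a limit.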

Compound 3, half-maximal inhibitory concentration: > 20000 nM
Compound 3 was reported as a limit (the forecaster's own chance of this, stated with the estimate: 85%); the middle value lies beyond the limit too.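

In this assay compound 3 gives > 20000 nM, which is a limit of the assay. Compound 1 also rests at a limit, so the step from compound 1 to compound 3, hydrogen in place of methoxy, cannot be read. The compounds shown leave open how 4-methoxyphenyl and phenyl would compare on a measured number, since none of them has one: the limit of > 20000 nM in this assay, at which 3 of the 3 values shown sit.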